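This account rests on a few compounds, and the source may have more. Where it says the series, first, only, none or still open, it means among the compounds named here.

Compound 1 `O=C(CI)NCCCCCCCCNc1ncnc2c1ncn2[C@@H]1O[C@H](COP(=O)(O)OP(=O)(O)OP(=O)(O)O)[C@@H](O)[C@H]1O`: 35%
Compound 2 `O=C(I)NCC(=O)NCCCCCCNc1ncnc2c1ncn2[C@@H]1O[C@H](COP(=O)(O)OP(=O)(O)OP(=O)(O)O)[C@@H](O)[C@H]1O`: 0%
Compound 3 `O=C(CI)NCCCCCC(=O)NCCCCCCNc1ncnc2c1ncn2[C@@H]1O[C@H](COP(=O)(O)OP(=O)(O)OP(=O)(O)O)[C@@H](O)[C@H]1O`: 0%

In an assay on isolated protein for inhibition of hexokinase-1 (Rattus norvegicus), with a stated time of 6 h, tested at 10 mM (on this read-out higher numbers stand for more inhibition at the one concentration tested (going by the name of the read-out) and lower numbers for less inhibition), compound 1 gives 35%, while compound 2 gives 0% and compound 3 gives 0%. Compound 3 therefore stands level with compound 2 at the digits shown, and the two share the lowest numbers of the three; its furthest neighbour is compound 1, as the step of a number 35 percentage points lower from compound 1 to compound 2 (beyond the scatter) and the step of no change at the digits printed from compound 2 to compound 3 (within the scatter) together show.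

Compound 4 `O=C(CI)NCCC(=O)NCCCCCCNc1ncnc2c1ncn2[C@@H]1O[C@H](COP(=O)(O)OP(=O)(O)OP(=O)(O)O)[C@@H](O)[C@H]1O` differs from compound 3 by ((iodomethyl)carbonyl)amino in place of 3-(((iodomethyl)carbonyl)amino)propyl on a saturated chain carbon, two bonds along the chain from a carbonyl carbon. The change alters the length of the chain between the two carbonyl carbons of the shared core. Going by the values given here, two measured steps bear on it: the step from compound 1 to compound 2, a number 35 percentage points lower from compound 1 to compound 2 (beyond the scatter), which replaced the single chain by a chain carrying a second amide, and the step from compound 2 to compound 3, no change at the digits printed from compound 2 to compound 3 (within the scatter), which lengthened that chain. Both compounds carrying two amides sit at the bottom of the range, so no step beyond the scatter is expected in this assay for a chain of intermediate length.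

Compound 4 is thus expected to give about 3%, with a range from 0% to 15%, corresponding to an expected step of a number 3 percentage points higher from compound 3 to compound 4 (within the scatter).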

Compound 4, a percentage reported as inhibition, at one concentration (the size of the read-out at that concentration, not a potency): 0%
Estimate against measurement, compound 4: 3 percentage points above; measured number inside the range.
By their numbers in this assay, from the lowest: compounds 2, 3 and 4 (each within the scatter of the next); then compound 1.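

In this assay, swapping 3-(((iodomethyl)carbonyl)amino)propyl for ((iodomethyl)carbonyl)amino on a saturated chain carbon, two bonds along the chain from a carbonyl carbon, gives no change at the digits printed from compound 3 to compound 4 (within the scatter), and the comparison with the other compound carrying a second amide gives no change at the digits printed from compound 2 to compound 4 (within the scatter), so altering the length of this chain at this position leaves the read-out flat across all three compounds. The large loss seen earlier also holds for this chain, with a number 35 percentage points lower from compound 1 to compound 4 (beyond the scatter), so the intermediate length does not recover anything of the inhibition shown by the chain without a second amide in compound 1. Nothing available here explains why the chains carrying a second amide give this result.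

Still open, going by these compounds, is whether a chain with an ether oxygen in place of the second amide, or an unbroken alkyl chain longer than that of compound 1, would hold or raise the inhibition. On these data alone, it also remains open whether (bromomethyl)carbonyl in place of (iodomethyl)carbonyl at the chain end would change the read-out on either type of chain.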